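From methyl to fluoro: estimating compound 4

The compounds below may be only part of what the source reports. "The series", "measured", "known", "first", "only" and "open" are said of these compounds alone.

Compound 1 `COc1ccccc1-c1csc2cnc(Nc3ccc(NC(=O)C4CCNCC4)cc3)nc12` gives 1060 nM
Compound 2 `COc1ccccc1-c1csc2cnc(Nc3ccc(NC(=O)[C@H]4CCCNC4)cc3)nc12` gives 300 nM
Compound 3 `COc1ccccc1-c1csc2cnc(Nc3ccc(C(=O)NC4CCNCC4)cc3C)nc12` gives 250 nM

These numbers come from a functional assay on U-87MG ATCC cells for inhibition, with U-87 MG (Homo sapiens) as the target, read by MTT assay, with a stated time of 72 h; on this read-out higher numbers stand for weaker inhibition and lower numbers for stronger inhibition. There, compound 3 at 250 nM lies within the usual scatter of compound 2 at 300 nM, and both numbers are clearly lower than that of compound 1 at 1060 nM.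

The next molecule, compound 4 `COc1ccccc1-c1csc2cnc(Nc3ccc(C(=O)NC4CCNCC4)cc3F)nc12`, changes one place, (fluoro in place of methyl on an aromatic carbon), with fluoro in place of methyl on an aromatic carbon, ortho to a large group and meta to a (piperidin-4-yl)carbamoyl group.

Among the measured compounds shown here, only one measured step exists between compounds that differ in one place. It is modest, a 3.5-fold lower number from compound 1 to compound 2 (0.55 log units; beyond the scatter), and it swaps piperidin-4-yl for piperidin-3-yl, so it does not test the methyl and fluoro swap. For the measured compounds named here, no measured pair does. That step does show that a single small change can move the number beyond the scatter, so the range has to stay wide.

With no evidence for a direction, the estimate stays close to compound 3 at 250 nM in this assay. The expected step is a 1.2-fold higher number from compound 3 to compound 4 (0.08 log units; within the scatter), which means no change beyond the scatter is anticipated. Compound 4 is expected at 300 nM, with an estimated range from 110 nM to 800 nM.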

Compound 4, half-maximal inhibitory concentration: 2370 nM
Beside the measured number, compound 4's estimate is 7.9-fold (0.90 log units) below it, outside the stated range (above it).
By their numbers in this assay, from the lowest: compounds 3 and 2 (each within the scatter of the next); then compound 1; then compound 4.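

On the aromatic carbon that sits ortho to a large group and meta to a (piperidin-4-yl)carbamoyl group, fluoro in place of methyl gives a 9.5-fold higher number from compound 3 to compound 4 (0.98 log units; beyond the scatter) in this assay. This exchanges one heavy atom for one heavy atom, with no ring, hydrogen-bond donor, hydrogen-bond acceptor or net charge entering or leaving, yet the number moves beyond the scatter, so this position responds to even a very small change in the group it carries. No measured property of these compounds bears on this result, and what lies behind the step remains unknown.

With only methyl and fluoro shown at this position, it stays open how a plain hydrogen, chloro or methoxy would read there, and so whether methyl or fluoro is the unusual case. Going by these compounds, it also stays open whether the same exchange would give a step of similar size in a compound carrying piperidin-3-yl in place of piperidin-4-yl.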